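This account rests on a few compounds, and the source may have more. Where it says the series, first, only, none or still open, it means among the compounds named here.

Of the compounds shown here, two that share a common core have so far been tested in a functional assay on HCT-116 cells (Homo sapiens) for cytotoxicity, read by sulforhodamine B assay; a lower number here means a stronger inhibitor of growth, a higher number a weaker inhibitor of growth. Within the data shown here, compound 1 `N#Cc1ccc(COC[C@H]2O[C@@H](n3c(NCc4ccc(Cl)c(Cl)c4)nc4c(N)ncnc43)[C@H](O)[C@@H]2O)cc1` gives 5000 nM in this assay, the lower of the two numbers measured so far. Compound 2 `Nc1ncnc2c1nc(NCc1ccc3ncccc3c1)n2[C@@H]1O[C@H](COCc2ccc(C(F)(F)F)cc2)[C@@H](O)[C@H]1O` gives 27000 nM in this assay, a gap to compound 1 that lies beyond the usual scatter; compound 2 differs from compound 1 in more than one place, so these two values show only that gap and point to no single cause.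

Compound 3 `Nc1ncnc2c1nc(NCc1ccc(Cl)c(Cl)c1)n2[C@@H]1O[C@H](COCc2cc(F)c(F)c(F)c2)[C@@H](O)[C@H]1O` has not yet been measured. It differs from compound 1 in one place: 3,4,5-trifluorophenyl in place of 4-cyanophenyl on a saturated chain carbon bound to an oxygen on a saturated carbon. Among the measured compounds shown here, no measured pair shows the effect of this exchange, so its direction cannot be read from the data. The step of a 1.2-fold higher number from compound 1 to compound 3 (0.08 log units; within the scatter) is expected to stay within the scatter, with a wide range around it. Compound 3 is expected to give 6000 nM in this assay, between 1500 nM and 20000 nM.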

Compound 3, concentration for 50% growth inhibition: 13000 nM
Compound 3: middle estimate off by 2.2-fold (0.34 log units), on the low side; measured number inside the range.
By their numbers in this assay, from the lowest: compound 1; then compound 3; then compound 2.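

In this assay, among these compounds, exchanging 4-cyanophenyl for 3,4,5-trifluorophenyl gives a 2.6-fold higher number from compound 1 to compound 3 (0.41 log units; beyond the scatter), the first step here that can be tied to a single place in the molecule. It shows that this position responds to the choice of aromatic group even with the rest of compound 1 unchanged, although the step is modest. No measurement shown here explains why the number rises, so this remains an observation about these two groups only.

The compounds shown do not reveal how an unsubstituted phenyl, a 4-methoxyphenyl or a pyridine ring would behave at this position, so the two groups cannot yet be placed on a wider scale. They also leave open how much of the gap between compound 1 and compound 2 comes from each of the places where those two differ.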